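The compounds below may be only part of what the source reports. "The series", "measured", "known", "first", "only" and "open" are said of these compounds alone.

Working notes on the series in a functional assay on K562 cells (Homo sapiens), read by MTT assay, with a stated time of 72 h; a higher number here means a weaker inhibitor, a lower number a stronger inhibitor.

Compound 1 `O=c1[nH]cnc2c1c(-c1cccs1)cn2[C@@H]1O[C@H](CO)[C@@H](O)[C@H]1O` carries a thiophen-2-yl group on the shared core. In this assay compound 1 gives only a limit, > 20000 nM, so its standing on the numbers is known only as a limit and not as a number. Compound 2 `Nc1nc2c(c(-c3cccs3)cn2[C@@H]2O[C@H](CO)[C@@H](O)[C@H]2O)c(=O)[nH]1` differs from compound 1 by a single added amino group, and in this assay compound 2 gives 16800 nM. The step of an at least 1.1-fold lower number from compound 1 to compound 2 (0.07 log units; that floor lies within the scatter) lies within the scatter. Compound 3 `CN(C)c1ncnc2c1c(-c1cccs1)cn2[C@@H]1O[C@H](CO)[C@@H](O)[C@H]1O` also gives only a limit in this assay, > 20000 nM. Among the measured compounds shown here, two of the three values so far sit at the limit of > 20000 nM in this assay, at which 2 of the 3 values shown sit, so the series as a whole is weak in this assay.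

Compound 4 `O=c1[nH]cnc2c1c(-c1ccccc1)cn2[C@@H]1O[C@H](CO)[C@@H](O)[C@H]1O` is not yet measured. The change from compound 1 to compound 4 is phenyl in place of thiophen-2-yl on an aromatic carbon. For the measured compounds named here, no measured step touches the aryl group on the core; the only measured step changes a different position and stays within the scatter. Nothing in the measured steps therefore argues for a step beyond the scatter in this assay, and the expected step of a number no higher from compound 1 to compound 4 (the limit leaves the size open) reflects that. Compound 4 is expected to give about 20000 nM, with a range from 9000 nM to 45000 nM, most likely again reported as a limit.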

Compound 4, half-maximal inhibitory concentration: > 20000 nM
Compound 4: no number, only a limit; the forecaster's own chance of this, stated with the estimate: 70%; the middle value sits exactly at the limit.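

In this assay compound 4 gives > 20000 nM, which is a limit and not a number. Compound 1 also stands only at a limit, so no step can be read from compound 1 to compound 4. The compounds shown leave open how phenyl and thiophen-2-yl on the shared core compare in this assay.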